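Demethylation step from compound 1 toward compound 3

This account rests on a few compounds, and the source may have more. Where it says the series, first, only, none or still open, it means among the compounds named here.

Measured so far:
compound 1 `CCc1cc2c(C(=O)c3ccc(OC)cc3)cc(OC)cc2o1`: 1.5%
compound 2 `CCc1oc2ccc(O)cc2c1C(=O)c1ccc(O)cc1`: 96.5%

In an assay for inhibition of solute carrier family 22 member 12 (Homo sapiens), read by scintillation counting, with a stated time of 60 min, tested at 50 uM (a lower number here means less inhibition, a higher number more inhibition at the concentration tested (going by the name of the read-out)), compound 1 gives 1.5%, the lowest of the two numbers in hand. The nearest measured neighbour, compound 2, gives 96.5%, a gap beyond the usual scatter. Among the measured compounds shown here, compound 1 and compound 2 differ in more than one place, so no single step between them can be read off; their two values show only that the compound carrying two hydroxy groups sits far higher.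

Compound 3 `CCc1cc2c(C(=O)c3ccc(O)cc3)cc(OC)cc2o1` is not yet measured. It differs from compound 1 by hydrogen in place of methyl on an oxygen on an aromatic ring. Since compound 2 gives 96.5% with hydroxy in place of methoxy at both ends, the step from compound 1 to compound 3 is expected to go upward, beyond the scatter, estimated at a number 43.5 percentage points higher from compound 1 to compound 3 (beyond the scatter). Compound 3 is expected to give about 45%, in a range from 10% to 85%.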

Compound 3, a percentage reported as inhibition, at one concentration (the size of the read-out at that concentration, not a potency): 62.4%
Compound 3: middle estimate off by 17.4 percentage points, on the low side; the range from low to high includes it.
By their numbers in this assay, from the lowest: compound 1; then compound 3; then compound 2.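

In this assay the series now has its first step in a single place: methoxy to hydroxy, on an oxygen on an aromatic ring, gives a number 60.9 percentage points higher from compound 1 to compound 3 (beyond the scatter) and counts as large. The gap between compound 1 and compound 2 could not be tied to any one place, whereas this step ties a large change to the loss of one methyl while the other methoxy of compound 3 stays in place. Nothing on hand accounts for the size of this step.

Still open, going by these compounds, is whether replacing the remaining methoxy of compound 3 with hydroxy moves the number further. Also open, on these data alone, is how an amine or a carboxylic acid in place of the new hydroxy, or a longer chain in place of the ethyl, would read.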